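A few compounds are considered here, and "the series" means these few. Any claim that something is new, unique, unknown or untested is made for them only; others in the source may bear on it.

Compound 1 `COc1ccc(C(=O)c2ccc(OC)c3c2OC(C)(C)C=C3)c(NC(=O)CO)c1` and compound 2 `COc1ccc(C(=O)c2ccc(OC)c3c2OC(C)(C)C=C3)c(NC(=O)CN)c1` share one core, while compound 3 `C=C(c1ccc2c(c1)C=CC(C)(C)O2)c1ccc(OC)cc1NC(=O)CO` and compound 4 `C=C(c1ccc2c(c1)C=CC(C)(C)O2)c1ccc(OC)cc1NC(=O)CN` share another; the difference between the two cores is not broken down here. In a functional assay on HCT-8 cells (Homo sapiens) for antiproliferative activity, read by MTT assay, with a stated time of 48 h (a lower number here means a stronger inhibitor, a higher number a weaker inhibitor), compound 1 gives 230 nM, compound 2 gives 370 nM and compound 3 gives 220 nM. Compound 1 and compound 2 differ by amino in place of hydroxy on a saturated chain carbon bound to a carbonyl carbon, and that change gave a 1.6-fold higher number from compound 1 to compound 2 (0.21 log units; within the scatter), a step that stayed within the scatter. Compound 3 and compound 4 differ by the same change, (amino in place of hydroxy on a saturated chain carbon bound to a carbonyl carbon), at the same place. Going by the values given here, since the only measured instance of this change moved the number so little, a step of like size is expected here, a 1.6-fold higher number from compound 3 to compound 4 (0.20 log units; within the scatter). Compound 4 is therefore estimated at 350 nM in this assay, with a likely range from 180 nM to 700 nM.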

Compound 4, half-maximal inhibitory concentration: 220 nM
The estimate for compound 4 lay 1.6-fold (0.20 log units) above the measured number, and the stated range covers the measured number.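

In this assay, amino in place of hydroxy on a saturated chain carbon bound to a carbonyl carbon gave no change at the digits printed from compound 3 to compound 4 (within the scatter). Set beside the earlier step, the change carried from one core to the other with no gap beyond the scatter: the same change on two cores in this assay, a 1.6-fold higher number (0.21 log units; within the scatter) from compound 1 to compound 2 and no change at the digits printed (within the scatter) from compound 3 to compound 4, 1.6-fold (0.21 log units) apart, within the scatter of two such steps. This shows that the two cores responded alike to this one change in this one cell assay, but two pairs establish no rule for other cores or other assays, and they do not explain why the numbers stayed so close.

The compounds shown leave open how a dimethylamino group, a carboxylic acid or a longer chain would behave at this place on either core.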